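Adding a Third Methoxy Group on the Carbonyl Side

The source may report more compounds than this note shows. Statements on the series, on what has been measured and on what is new or still open speak of the compounds shown alone.

Three compounds share one core. Compound 1 `COc1cc(-c2cc(/C=C/C(=O)c3ccc(Cl)c(Cl)c3)[nH]n2)cc(OC)c1OC` gives 66000 nM in a functional assay on SK-MEL-28 cells (Homo sapiens) for inhibition, read by sulforhodamine B assay, with a stated time of 48 h; on this read-out higher numbers stand for weaker inhibition of growth and lower numbers for stronger inhibition of growth. Compound 2 `COc1ccc(C(=O)/C=C/c2cc(-c3cc(OC)c(OC)c(OC)c3)n[nH]2)cc1OC` gives 3340 nM in this assay, the lowest number shown, though compound 3 `COc1ccc(C(=O)/C=C/c2cc(-c3cc(OC)c(OC)c(OC)c3)n[nH]2)cc1` with 4420 nM sits within the scatter of it. The steps of a 20-fold lower number from compound 1 to compound 2 (1.30 log units; beyond the scatter) and a 15-fold lower number from compound 1 to compound 3 (1.17 log units; beyond the scatter) were large, whereas a 1.3-fold higher number from compound 2 to compound 3 (0.12 log units; within the scatter) stayed within the scatter. Compound 4 `COc1cc(C(=O)/C=C/c2cc(-c3cc(OC)c(OC)c(OC)c3)n[nH]2)cc(OC)c1OC` differs from compound 2 by methoxy in place of hydrogen on an aromatic carbon. Only the hydrogen-for-methoxy exchange between compound 2 and compound 3 bears on this step, and because that step a 1.3-fold higher number from compound 2 to compound 3 (0.12 log units; within the scatter) stayed within the scatter, no step beyond the scatter is expected in this assay. Compound 4 is therefore estimated at 3500 nM, between 1200 nM and 10000 nM, an expected step of a 1.0-fold higher number from compound 2 to compound 4 (0.02 log units; within the scatter).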

Compound 4, concentration for total growth inhibition: 3330 nM
Compound 4: the middle estimate sits 1.1-fold (0.02 log units) above what was measured; measured number inside the range.
By their numbers in this assay, from the lowest: compounds 4, 2 and 3 (each within the scatter of the next); then compound 1.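

At this aromatic carbon, ortho to a methoxy group, adding methoxy gave a 1.0-fold lower number from compound 2 to compound 4 (0.00 log units; within the scatter) in this assay and so produced no step beyond the scatter. The hydrogen-for-methoxy exchange on the same ring, a 1.3-fold higher number from compound 2 to compound 3 (0.12 log units; within the scatter), also stayed within the scatter, so two separate single changes of this kind on that ring now show no measurable shift. No evidence offers an explanation for this result. The compounds shown leave open whether a hydroxyl, an amine or a longer chain such as ethoxy at this carbon would give a step beyond the scatter.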